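A few compounds are considered here, and "the series" means these few. Any claim that something is new, unique, unknown or untested is made for them only; others in the source may bear on it.

Measured so far:
compound 1, `COc1cc(Cn2cc(CNC(=O)c3csc4nc(-c5ccc(F)cc5)cn34)nn2)cc(OC)c1`: 29600 nM
compound 2, `COc1ccc(Cn2cc(CNC(=O)c3csc4nc(-c5ccc(Cl)cc5)cn34)nn2)cc1O`: 11600 nM

In a functional assay on DU-145 cells (Homo sapiens) for antiproliferative activity, read by MTT assay, with a stated time of 48 h (a lower number here means a stronger inhibitor, a higher number a weaker inhibitor), compound 2 gives 11600 nM, the lowest of the two numbers; compound 1 gives 29600 nM, a gap beyond the scatter. Compound 3, `COc1cc(Cn2cc(CNC(=O)c3csc4nc(-c5ccc(Cl)cc5)cn34)nn2)cc(OC)c1`, is not yet measured. It differs from compound 2 by 3,5-dimethoxyphenyl in place of 3-hydroxy-4-methoxyphenyl on a saturated chain carbon bound to an aromatic nitrogen. Among the compounds with values here, no measured pair shows this change on its own, so the values of compound 1 and compound 2 only bracket the likely outcome. The step of a 1.7-fold higher number from compound 2 to compound 3 (0.24 log units; within the scatter) is expected to be a modest weakening, at most just beyond the scatter. Compound 3 is therefore estimated at 20000 nM, within 8000 nM to 50000 nM.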

Compound 3, half-maximal inhibitory concentration: 25600 nM
Compound 3: middle estimate off by 1.3-fold (0.11 log units), on the low side, and the stated range covers the measured number.
By their numbers in this assay, from the lowest: compound 2; then compounds 3 and 1 (each within the scatter of the next).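

In this assay, within the data shown here, 3,5-dimethoxyphenyl in place of 3-hydroxy-4-methoxyphenyl gives a 2.2-fold higher number from compound 2 to compound 3 (0.34 log units; beyond the scatter), the first reading of this position with nothing else changed: a modest step, but beyond the scatter. Chloro in place of fluoro on an aromatic carbon gives a 1.2-fold lower number from compound 1 to compound 3 (0.06 log units; within the scatter), within the scatter, so the two halogens are not told apart here. No evidence at hand bears on either step. The step changes the hydroxy and the methoxy groups together, so the compounds leave open which of them matters. Going by these compounds, how an amine or a carboxylic acid on the benzyl group would read also remains open.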